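Hydroxyalkyl Thioether in Place of the Amide Chain

The source may hold more compounds than are shown below. What is called first, only, known or untested is meant among the compounds shown, and "the series" means these compounds.

Three measured compounds share one core and differ only in the group carried on the sulfur. In a functional assay on HT cells (Homo sapiens) for antiproliferative activity, read by fluorescence, with a stated time of 72 h (on this read-out lower numbers stand for stronger inhibition of growth and higher numbers for weaker inhibition of growth), compound 3 `CC(C)c1n[nH]c2c(NCc3ccc(-c4ccccn4)cc3)nc(SCCC(N)=O)nc12` gives 120 nM, the second highest of the three numbers. Compound 1 `CC(O)CSc1nc(NCc2ccc(-c3ccccn3)cc2)c2[nH]nc(C(C)C)c2n1` gives 62 nM, and the step of a 1.9-fold higher number from compound 1 to compound 3 (0.29 log units; within the scatter) lies within the scatter. Compound 2 `CC(C)c1n[nH]c2c(NCc3ccc(-c4ccccn4)cc3)nc(SCCNC(=N)N)nc12` gives 390 nM; the steps of a 6.3-fold higher number from compound 1 to compound 2 (0.80 log units; beyond the scatter) and a 3.3-fold lower number from compound 2 to compound 3 (0.51 log units; beyond the scatter) are modest but real. Compound 4 `CCC(CO)Sc1nc(NCc2ccc(-c3ccccn3)cc2)c2[nH]nc(C(C)C)c2n1` has not yet been measured; its change is 1-(hydroxymethyl)propyl in place of 2-carbamoylethyl on a sulfur. The step of a 1.9-fold higher number from compound 1 to compound 3 (0.29 log units; within the scatter) bears most closely on this. It is the reverse of a similar exchange between carbamoylmethyl and 1-hydroxyethyl and stayed within the scatter. The expected step of a 1.5-fold lower number from compound 3 to compound 4 (0.18 log units; within the scatter) is therefore small. Compound 4 is estimated at 80 nM, within a range from 30 nM to 250 nM.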

Compound 4, concentration for 50% growth inhibition: 255 nM
For compound 4 the middle estimate is 3.2-fold (0.50 log units) below the measured one, and the stated range ends below it.
By their numbers in this assay, from the lowest: compounds 1 and 3 (each within the scatter of the next); then compounds 4 and 2 (each within the scatter of the next).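

In this assay, two hydroxyl-bearing groups on the sulfur prove not to be interchangeable: 1-(hydroxymethyl)propyl in place of 2-hydroxypropyl gives a 4.1-fold higher number from compound 1 to compound 4 (0.61 log units; beyond the scatter). Replacing 2-carbamoylethyl also counts, with a 2.1-fold higher number from compound 3 to compound 4 (0.33 log units; beyond the scatter), whereas a 1.5-fold lower number from compound 2 to compound 4 (0.18 log units; within the scatter) leaves those two compounds inseparable, so carrying a hydroxyl does not by itself keep the number low. Nothing measured here explains these differences. On these data alone, how a carboxylic acid, a simple amine or a longer chain ending in hydroxyl would behave on this sulfur remains open.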